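The source may hold more compounds than are shown below. What is called first, only, known or untested is meant among the compounds shown, and "the series" means these compounds.

Measured so far in a functional assay on HCT-116 cells (Homo sapiens) for antiproliferative activity, read by MTT assay, with a stated time of 72 h; on this read-out higher numbers stand for weaker inhibition and lower numbers for stronger inhibition:
compound 1 `COc1c(NS(=O)(=O)C2CC2)cc(-c2ccc3nc(NC(=O)C4CC4)sc3c2)cc1C(N)=O`, compound 1 gives 14500 nM
compound 2 `COc1c(NS(=O)(=O)c2ccc(F)cc2)cc(-c2ccc3nc(NC(=O)C4CC4)sc3n2)cc1C(N)=O`, compound 2 gives 2500 nM
compound 3 `NC(=O)c1cc(NS(=O)(=O)c2ccc(F)cc2)cc(-c2ccc3nc(NC(=O)C4CC4)sc3c2)c1`, compound 3 gives > 50000 nM

The value of compound 3 in this assay is a limit of the assay, not a number (the limit of > 50000 nM in this assay, at which 1 of the 3 values shown sits). Compound 1 and compound 2 both return numbers in this assay, and compound 3 is the only one of the three at the limit. For the measured compounds named here, no two of the measured compounds differ in one place only, so no measured step is available to size the change ahead.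

Compound 4 `NC(=O)c1cc(-c2ccc3nc(NC(=O)C4CC4)sc3c2)cc(NS(=O)(=O)c2ccc(F)cc2)c1Cl` differs from compound 3 by chloro in place of hydrogen on an aromatic carbon. With compound 3 at the limit, any measurable value for compound 4 would count as a gain; the expected step is an at least 2.0-fold lower number from compound 3 to compound 4 (0.30 log units; that floor lies within the scatter), with the possibility that compound 4 too reports only a limit. The estimate for compound 4 in this assay is 25000 nM, between 6000 nM and 80000 nM.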

Compound 4, half-maximal inhibitory concentration: 11400 nM
Compound 4: middle estimate off by 2.2-fold (0.34 log units), on the high side; low and high end bracket the measured number.
By their numbers in this assay, from the lowest: compound 2; then compounds 4 and 1 (each within the scatter of the next). At a limit, above all of these: compound 3.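

In this assay, chloro in place of hydrogen on an aromatic carbon, ortho to a ((4-fluorophenyl)sulfonyl)amino group and ortho to a carbamoyl group, gives an at least 4.3-fold lower number from compound 3 to compound 4 (0.64 log units; beyond the scatter). Compound 3 reports a limit, not a number, so the size of this step is only a floor: the limit of > 50000 nM in this assay, at which 1 of the 4 values shown sits.

For the compounds shown here, this is the first measured step, and it shows that a single chloro at this position is enough to return a number. As far as these compounds go, how fluoro, methyl or an amine at the same position would read remains open. From the compounds shown here alone, whether the step holds with a cyclopropylsulfonyl group in place of the 4-fluorophenylsulfonyl group is also open.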